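This account rests on a few compounds, and the source may have more. Where it says the series, first, only, none or still open, it means among the compounds named here.

Measured compounds:
compound 1 `CCCOC(=O)Nc1ccc([Se]C#N)cc1` — 8000 nM
compound 2 `CCCCOC(=O)Nc1ccc([Se][Se]c2ccc(NC(=O)OCCCC)cc2)cc1` — 17300 nM
compound 3 `N#C[Se]c1ccc(NC(=O)Oc2ccc(Cl)cc2)cc1` — 6000 nM

All three were run in a functional assay on MCF7 cells (Homo sapiens) for cytotoxicity, read by MTT assay, with a stated time of 72 h; a higher number here means a weaker inhibitor of growth, a lower number a stronger inhibitor of growth. Compound 1 gives 8000 nM, the second highest of the three numbers. Compound 3 gives 6000 nM, which lies within the scatter of compound 1, so no order between the two is claimed. Compound 2 gives 17300 nM, a higher number that lies beyond the scatter of compound 1; compound 2 differs from compound 1 in more than one place, so the two values are only set side by side here.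

Compound 4, `CCCCOC(=O)Nc1ccc([Se]C#N)cc1`, has not yet been measured in this assay. The change from compound 1 is:

methyl in place of hydrogen on a saturated chain carbon, three bonds along the chain from an oxygen next to a carbonyl group

Within the data shown here, no pair of measured compounds shows this single change, so nothing in the data fixes its size. The expectation is a step of no more than the usual scatter, in either direction. The step from compound 1 to compound 4 is estimated as no change at the digits printed from compound 1 to compound 4 (within the scatter). Compound 4 is therefore expected to give about 8000 nM in this assay, within the range 4000 nM to 16000 nM.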

Compound 4, concentration for 50% growth inhibition: 6600 nM
Compound 4: middle estimate off by 1.2-fold (0.08 log units), on the high side; measured number inside the range.
By their numbers in this assay, from the lowest: compounds 3, 4 and 1 (each within the scatter of the next); then compound 2.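

Among these compounds, the step of a 1.2-fold lower number from compound 1 to compound 4 (0.08 log units; within the scatter) in this assay is the first direct reading of methyl in place of hydrogen on a saturated chain carbon, three bonds along the chain from an oxygen next to a carbonyl group. Going from propyl to butyl at this position therefore gives no order between the two compounds, and this single pair shows no sensitivity to the added methyl. Nothing on hand explains the size of this step.

On these data alone, whether a longer chain, a branched chain, or a chain ending in an amine or a carboxylic acid would stay within the scatter of compound 4 remains open. Also open is how the propyl to butyl change reads on the core of compound 2, where only the butyl member is shown.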